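The source may hold more compounds than are shown below. What is called first, only, known or untested is meant among the compounds shown, and "the series" means these compounds.

In a functional assay on MCF7 cells (Homo sapiens) for antiproliferative activity, read by MTT assay, with a stated time of 48 h (a lower number here means a stronger inhibitor, a higher number a weaker inhibitor), compound 1 (`Fc1ccc(-c2nn(-c3ccccc3)cc2-c2nc3cc(Cl)ccc3[nH]2)cc1`) gives 2230 nM, and compound 2 (`Fc1ccc2[nH]c(-c3cn(-c4ccccc4)nc3-c3ccc(Cl)cc3)nc2c1`) gives 2830 nM. Within the data shown here, these two values lie within the usual scatter of each other, so compound 2 stands level with compound 1 on the numbers so far. Compound 3 (`Clc1ccc(-c2nn(-c3ccccc3)cc2-c2nc3cc(Cl)ccc3[nH]2)cc1`) has not yet been measured. It carries chloro in place of fluoro on an aromatic carbon of compound 2, a six-membered aromatic ring of carbon only that is part of a fused system of two rings: chloro in place of fluoro on an aromatic carbon. Among the measured compounds shown here, no measured pair in this small set isolates such a change, so the data offer no direct guide to its size. No shift beyond the scatter is expected in this assay. The expected change is a 1.2-fold lower number from compound 2 to compound 3 (0.07 log units; within the scatter), an estimate that stays within the scatter. For compound 3 the estimated value is 2400 nM, with an expected range from 1100 nM to 5000 nM.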

Compound 3, half-maximal inhibitory concentration: 1170 nM
Compound 3: the middle estimate sits 2.1-fold (0.31 log units) above what was measured, within the range that was stated.
By their numbers in this assay, from the lowest: compounds 3, 1 and 2 (each within the scatter of the next, the first and the last beyond it).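

With the core held constant, the exchange of fluoro for chloro on the aromatic carbon of the fused two-ring system is now isolated in this assay and gives a 2.4-fold lower number from compound 2 to compound 3 (0.38 log units; beyond the scatter) as a modest step that lies beyond the scatter. The same exchange at a different aromatic carbon gives a 1.9-fold lower number from compound 1 to compound 3 (0.28 log units; within the scatter) and stays within the scatter, so only the place in the fused system shows a shift that can be read. No measurement offered here explains this step.

The compounds shown leave open whether a bromo or a methoxy group on that carbon of the fused system would lower the number further. They also leave open how an amine at the same carbon would compare with chloro or fluoro.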